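Methyl on the sulfonyl phenyl of compound 1

The compounds below may be only part of what the source reports. "The series", "measured", "known", "first", "only" and "open" are said of these compounds alone.

Measured so far:
compound 1 `CC1CCN(c2c(S(=O)(=O)c3ccccc3)cnc3cc(Cl)ccc23)CC1` — 93%
compound 2 `NS(=O)(=O)N1CCN(c2c(S(=O)(=O)c3cccc(F)c3)cnc3cc(F)ccc23)CC1` — 1.9%
compound 3 `CC1CCN(c2c(S(=O)(=O)c3ccccc3)cnc3ccccc23)CC1` — 89.2%

In an assay on isolated protein for displacement of a labelled ligand from metabotropic glutamate receptor 5 (Homo sapiens), with a stated time of 60 min, tested at 1 uM (a lower number here means less inhibition, a higher number more inhibition at the concentration tested (going by the name of the read-out)), compound 1 gives the highest of the three numbers. Compound 3 sits nearest, with the step of a number 3.8 percentage points lower from compound 1 to compound 3 (within the scatter), so the chloro on the aromatic carbon does not separate the two. Compound 2 lies far below; it differs from compound 1 in several places at once, so its low number cannot be tied to any single change.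

Compound 4 `Cc1ccc(S(=O)(=O)c2cnc3cc(Cl)ccc3c2N2CCC(C)CC2)cc1` is the next compound for this assay. It differs from compound 1 by methyl in place of hydrogen on an aromatic carbon. Among the measured compounds shown here, no measured pair shows this methyl for hydrogen exchange, so the only step that bears on the new compound is the one from compound 1 to compound 3, which stayed within the scatter and suggests that a small change at the edge of compound 1 leaves the read-out largely where it is. On that basis a small drop or none at all is expected, a number 5 percentage points lower from compound 1 to compound 4 (within the scatter) in this assay. Compound 4 is therefore estimated at 88%, with a range of 70% to 97%.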

Compound 4, a percentage reported as inhibition, at one concentration (the size of the read-out at that concentration, not a potency): 94%
Estimate against measurement, compound 4: 6 percentage points below, within the range that was stated.
By their numbers in this assay, from the lowest: compound 2; then compounds 3, 1 and 4 (each within the scatter of the next).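

In this assay the change from phenyl to 4-methylphenyl gives a number 1 percentage points higher from compound 1 to compound 4 (within the scatter), and this is the only single-place change on the sulfonyl phenyl among the compounds shown. One added carbon, para to a large group, therefore leaves the read-out unmoved at this position, as a number 3.8 percentage points lower from compound 1 to compound 3 (within the scatter) did for the loss of chloro elsewhere on the core of compound 1. Nothing available explains why the read-out holds at this position.

Compound 1 and compound 4 both sit near the top of the percentage scale at a single concentration, so any difference in potency between them remains unresolved. Also open, on these data alone, is whether a methoxy group, an amine or a carboxylic acid in place of the methyl would keep the read-out at this level.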